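A Fluorine Shift from Compound 3 to Compound 4

A few compounds are considered here, and "the series" means these few. Any claim that something is new, unique, unknown or untested is made for them only; others in the source may bear on it.

Three compounds built on a shared core, all carrying a 2-fluorophenyl group, have been tested in a functional assay on HeLa cells (Homo sapiens) for cytotoxicity, read by MTT assay, with a stated time of 24 h (a lower number here means a stronger inhibitor, a higher number a weaker inhibitor), so far. Compound 1 `COc1cc(/C=C2\CN(C)C/C(=C\c3ccccc3F)C2=O)cc(OC)c1` gives 5450 nM and compound 2 `CN1C/C(=C\c2ccc(C(C)(C)C)cc2)C(=O)/C(=C/c2ccccc2F)C1` gives 15500 nM in this test. Compound 3 `CN1C/C(=C\c2cccc([N+](=O)[O-])c2)C(=O)/C(=C/c2ccccc2F)C1` reaches 2340 nM as the lowest number of the three, beyond the scatter from both others. Among the measured compounds shown here, compound 4 `CN1C/C(=C\c2ccc(F)cc2)C(=O)/C(=C/c2cccc([N+](=O)[O-])c2)C1` is still unmeasured and carries 4-fluorophenyl in place of 2-fluorophenyl on a double-bonded chain carbon bound to a double-bonded ring carbon as its only change. For the measured compounds named here, no measured pair shows this kind of change, so the estimated step of a 1.3-fold higher number from compound 3 to compound 4 (0.11 log units; within the scatter) is expected to stay within the scatter. In this assay compound 4 is expected near 3000 nM with an estimated range from 1100 nM to 8000 nM for now.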

Compound 4, half-maximal inhibitory concentration: 6250 nM
Estimate against measurement, compound 4: 2.1-fold (0.32 log units) below; the measured number falls inside the stated range.
By their numbers in this assay, from the lowest: compound 3; then compounds 1 and 4 (each within the scatter of the next); then compound 2.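

In this assay, among the compounds shown here, the swap gives a 2.7-fold higher number from compound 3 to compound 4 (0.43 log units; beyond the scatter), the first step here that can be read from one single change. It shows that where the fluorine sits on this ring matters on its own, even though both compounds hold the same atoms, with 2-fluorophenyl giving the lower number in this pair. Nothing measured here explains the shift.

One pair cannot tell whether the same shift would appear with another group on the opposite arm of the shared core. On these data alone, how a phenyl ring carrying an amine or a carboxylic acid in place of the fluorine would behave at this place also stays open.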